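Amide aryl change from compound 2 to compound 3

A few compounds are considered here, and "the series" means these few. Any claim that something is new, unique, unknown or untested is made for them only; others in the source may bear on it.

Measured so far in a functional assay on HeLa cells (Homo sapiens) for inhibition, read by MTT assay, with a stated time of 24 h; on this read-out higher numbers stand for weaker inhibition and lower numbers for stronger inhibition:

compound 1 `O=C(Cn1c(=O)c(/C=C\c2ccncc2)nc2ccccc21)Nc1ccccc1`: > 100000 nM
compound 2 `Cc1ccccc1NC(=O)Cn1c(=O)c(/C=C\c2ccncc2)nc2ccccc21`: > 100000 nM

Compound 2 stands at a limit of this assay, not at a number. Compound 1 likewise sits at a limit. Among the compounds with values here, the single measured step, a step that the two limits leave unreadable from compound 1 to compound 2, is unreadable because both ends rest on the limit (the limit of > 100000 nM in this assay, at which 2 of the 2 values shown sit).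

Compound 3 `COc1ccc(NC(=O)Cn2c(=O)c(/C=C\c3ccncc3)nc3ccccc32)cc1OC` carries 3,4-dimethoxyphenyl in place of 2-methylphenyl on an amide-type nitrogen. No readable step bears on this change. Compound 3 is expected to remain at the limit, with the step that the limit leaves unreadable from compound 2 to compound 3 estimated as none beyond the scatter. The estimate for compound 3 is 150000 nM, between 50000 nM and 500000 nM.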

Compound 3, half-maximal inhibitory concentration: > 100000 nM
Compound 3 was reported as a limit; the forecaster's own chance of this, stated with the estimate: 85%; the middle value does not contradict the limit.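

No new step can be read among compound 1, compound 2 and compound 3, since all three rest on one limit: the limit of > 100000 nM in this assay, at which 3 of the 3 values shown sit.

Whether any group on the amide-type nitrogen gives a readable value in this assay stays open with the compounds shown.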